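Chloro Replacing Hydrogen in a Carboxy-Bearing Analogue

The compounds below may be only part of what the source reports. "The series", "measured", "known", "first", "only" and "open" are said of these compounds alone.

Measured so far in a functional assay on the whole organism (strain albino) for inhibition, with Rattus norvegicus as the target, read by paw edema, with stated times of 1 h and 2 h, at a dose of 100 mg/kg by the oral route; on this read-out higher numbers stand for more inhibition at the one dose given (going by the name of the read-out) and lower numbers for less inhibition:
Compound 1 `N#Cc1c(-c2ccccc2)nc(SCC(=O)Nn2c(COc3ccc(Cl)cc3Cl)nc3ccccc3c2=O)[nH]c1=O` gives 86%.
Compound 2 `N#Cc1c(-c2ccc(Cl)cc2)nc(SCC(=O)Nn2c(COc3ccc(Cl)cc3Cl)nc3ccccc3c2=O)[nH]c1=O` gives 64.9%.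
Compound 3 `O=C(CSc1nc(-c2ccccc2)c(C(=O)O)c(=O)[nH]1)Nn1c(COc2ccc(Cl)cc2Cl)nc2ccccc2c1=O` gives 68.4%.

Compound 3 stands second highest of the three numbers. Its value and that of compound 2 lie within the usual scatter of each other, so no order between those two can be claimed. Against compound 1 the gap is real: a number 17.6 percentage points lower from compound 1 to compound 3 (beyond the scatter).

Compound 4 `O=C(CSc1nc(-c2ccc(Cl)cc2)c(C(=O)O)c(=O)[nH]1)Nn1c(COc2ccc(Cl)cc2Cl)nc2ccccc2c1=O` has not yet been measured. It differs from compound 3 in one place: chloro in place of hydrogen on an aromatic carbon.

Among the compounds with values here, one measured step bears directly on this change. Between two compounds that carry the cyano group rather than the carboxy group, the same replacement gave a number 21.1 percentage points lower from compound 1 to compound 2 (beyond the scatter), a drop beyond the scatter. Within the data shown here, since that is the only example of this change in the set, it is uncertain how faithfully it carries over to the carboxy-bearing pair, and the range below is kept wide for that reason.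

A drop of broadly similar size is expected from compound 3 to compound 4, namely a number 18.4 percentage points lower from compound 3 to compound 4 (beyond the scatter). Compound 4 is therefore estimated at 50%, with an expected range from 35% to 65%.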

Compound 4, a percentage reported as inhibition, in the whole organism at one dose (the size of the read-out at that dose, not a potency): 61.4%
Beside the measured number, compound 4's estimate is 11.4 percentage points below it; low and high end bracket the measured number.
By their numbers in this assay, from the lowest: compounds 4, 2 and 3 (each within the scatter of the next); then compound 1.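

On the carboxy-bearing core, the change from phenyl to 4-chlorophenyl gives a number 7 percentage points lower from compound 3 to compound 4 (within the scatter), so in this assay this pair shows no clear loss with the chloro. The effect of adding chloro at this position therefore depends on the rest of the molecule, and the size of the step differs clearly between the two cores: the same change on two cores in this assay, a number 21.1 percentage points lower (beyond the scatter) from compound 1 to compound 2 and a number 7 percentage points lower (within the scatter) from compound 3 to compound 4, 14.1 percentage points apart, beyond the scatter of two such steps

Read the other way, replacing cyano with carboxy gives a number 3.5 percentage points lower from compound 2 to compound 4 (within the scatter) when the 4-chlorophenyl group is present, so the two changes do not simply add up: the same change on two cores in this assay, a number 17.6 percentage points lower (beyond the scatter) from compound 1 to compound 3 and a number 3.5 percentage points lower (within the scatter) from compound 2 to compound 4, 14.1 percentage points apart, beyond the scatter of two such steps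

The compounds shown leave open whether this dependence is particular to chloro, or whether a fluoro, a methoxy or an amino group on the same aromatic carbon would behave the same way on each core. Since each compound has a single reading at one dose, they also leave open how the four compare in potency, which would take readings across a range of doses.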